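From Isopentyl to 4-Chlorophenyl on the Aromatic Nitrogen

The source may report more compounds than this note shows. Statements on the series, on what has been measured and on what is new or still open speak of the compounds shown alone.

The series centres on a conjugated diketo acid chain attached to a fused bicyclic core. Compound 1 `CCOC(=O)C(=O)CC(=O)/C=C/c1cn(CCC(C)C)c2ccccc12` carries that chain as an ethyl ester, and in a functional assay on MOLT-4 cells (Homo sapiens) for inhibition, read by MTT assay, with a stated time of 48 h (a lower number here means a stronger inhibitor, a higher number a weaker inhibitor), the outcome for compound 1 is "not determined" (no result reported). Compound 2 `CC(C)CCn1cc(/C=C/C(=O)CC(=O)C(=O)O)c2ccccc21` is the free acid with the same isopentyl group on the aromatic nitrogen, and in this assay compound 2 gives 20000 nM. Within the data shown here, that is the only number available, so compound 2 is the sole reference point, and it stands as a weak inhibitor.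

Compound 3 `O=C(/C=C/c1cn(-c2ccc(Cl)cc2)c2ccccc12)CC(=O)C(=O)O` keeps the free acid and the core but changes the substituent on the aromatic nitrogen: 4-chlorophenyl in place of isopentyl on an aromatic nitrogen. Among the measured compounds shown here, no measured pair shows what such a change does here, so any expectation rests on compound 2 alone. The step is expected to be a 1.7-fold lower number from compound 2 to compound 3 (0.22 log units; within the scatter), a modest move toward stronger inhibition that may not exceed the usual scatter. In this assay compound 3 is therefore estimated at 12000 nM, with a plausible range from 3000 nM to 50000 nM.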

Compound 3, half-maximal inhibitory concentration: 27000 nM
Estimate against measurement, compound 3: 2.3-fold (0.35 log units) below, and the stated range covers the measured number.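

Among these compounds, this pair gives the first reading of the aromatic nitrogen as a place of change: in this assay the step is a 1.4-fold higher number from compound 2 to compound 3 (0.13 log units; within the scatter), so compound 2 and compound 3 cannot be told apart. Isopentyl, which has no ring, and 4-chlorophenyl, which brings one six-membered aromatic ring of carbon only, therefore give the same result within the scatter in this cell assay, and the free acid chain and the shared core stay as they were. So a ring in place of an open chain at this position, with a chlorine added, does not by itself give a distinguishable number, and no measurement offered here accounts for that outcome.

On these data alone, what remains open is whether any other group on this nitrogen, such as benzyl, plain phenyl, a longer alkyl chain or a chain ending in an amine, would give a number clearly apart from these two. The compounds shown also leave open how the ethyl ester compares with the free acid, since compound 1 provides no number to set against compound 2.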